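A few compounds are considered here, and "the series" means these few. Any claim that something is new, unique, unknown or untested is made for them only; others in the source may bear on it.

Three compounds with the same core, differing only in the group on a double-bonded chain carbon bound to a double-bonded chain carbon, have been measured in a functional assay on HeLa cells (Homo sapiens) for cytotoxicity, read by MTT assay, with a stated time of 48 h; on this read-out lower numbers stand for stronger inhibition and higher numbers for weaker inhibition. Compound 1 (`Cc1ccc(C)c(/C=C/[C@](C)(O)CC[C@@H]2[C@@]3(C)CCCC(C)(C)[C@@H]3CC[C@@]2(C)O)c1`) gives 3380 nM, compound 2 (`CC1(C)CCC[C@]2(C)[C@@H](CC[C@@](C)(O)/C=C/c3ccc(Cl)nc3)[C@](C)(O)CC[C@@H]12`) gives 3680 nM, and compound 3 (`Cc1cccc(C)c1/C=C/[C@](C)(O)CC[C@@H]1[C@@]2(C)CCCC(C)(C)[C@@H]2CC[C@@]1(C)O`) gives 3460 nM. Compound 3 therefore stands with the other two, and the numbers set no order among them.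

The next compound is compound 4 (`CC1(C)CCC[C@]2(C)[C@@H](CC[C@@](C)(O)/C=C/c3ccc(F)cc3)[C@](C)(O)CC[C@@H]12`), which carries 4-fluorophenyl in place of 2,6-dimethylphenyl at that same place: 4-fluorophenyl in place of 2,6-dimethylphenyl on a double-bonded chain carbon bound to a double-bonded chain carbon. Among the compounds with values here, no measured compound yet carries 4-fluorophenyl, so only the earlier exchanges at this place bear on the change. Replacing 2,5-dimethylphenyl with 2,6-dimethylphenyl gave a 1.0-fold higher number from compound 1 to compound 3 (0.01 log units; within the scatter). Replacing it with 6-chloropyridin-3-yl gave a 1.1-fold higher number from compound 1 to compound 2 (0.04 log units; within the scatter), and the remaining exchange gave a 1.1-fold lower number from compound 2 to compound 3 (0.03 log units; within the scatter). All of these lie within the scatter, so no step beyond the scatter is expected in this assay, and no direction can be favoured. The expected change is an estimated 1.0-fold higher number from compound 3 to compound 4 (0.00 log units; within the scatter). For compound 4 the estimated value is 3500 nM, with an expected range from 1800 nM to 7000 nM.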

Compound 4, half-maximal inhibitory concentration: 3460 nM
Estimate against measurement, compound 4: 1.0-fold (0.00 log units) above; the measured number falls inside the stated range.
By their numbers in this assay, from the lowest: compounds 1, 3, 4 and 2 (each within the scatter of the next).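

In this assay, 4-fluorophenyl gave no change at the digits printed from compound 3 to compound 4 (within the scatter), a 1.1-fold lower number from compound 2 to compound 4 (0.03 log units; within the scatter) and a 1.0-fold higher number from compound 1 to compound 4 (0.01 log units; within the scatter), so this group, the first here to carry fluorine on a ring of carbon only and to have no methyl groups, also sets no order against the three earlier ones. The earlier compounds had shown this flat picture only for 2,5-dimethylphenyl, 2,6-dimethylphenyl and 6-chloropyridin-3-yl; at this place on a double-bonded chain carbon bound to a double-bonded chain carbon it now holds for all four groups shown, and none of the four steps away from the others lies beyond the scatter. Nothing available explains why these exchanges leave the number in place.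

All four compounds keep a six-membered aromatic ring at this place, so they leave open whether a carboxylic acid, an amine or a longer saturated carbon chain there would move the number beyond the scatter. They also leave open whether any ring is needed at all, as a plain hydrogen at the end of the double bond does not appear among them.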